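A Basic Amine in Place of a Carboxylic Acid

The compounds below may be only part of what the source reports. "The series", "measured", "known", "first", "only" and "open" are said of these compounds alone.

Compound 1, `CN(C)CCCn1c(Cc2nn(C)c(=O)c3ccccc23)nnc1SCCCCCCCC(=O)Nc1ccc(Cl)cc1Cl`: 5500 nM
Compound 2, `Cn1nc(Cc2nnc(SCCCCCCCC(=O)Nc3ccc(Cl)cc3Cl)n2CCC(=O)O)c2ccccc2c1=O`: > 30000 nM
Compound 3, `Cn1c(Cc2nn(CCC(=O)O)c(=O)c3ccccc23)nnc1SCC(=O)Nc1ccc(Cl)cc1Cl`: > 30000 nM

In an assay on 32D cells for inhibition of interleukin-15 (Mus musculus), read by resazurin assay, with stated times of 30 min and 2.5 days, in the presence of a further agent that is not named here (a lower number here means a stronger inhibitor, a higher number a weaker inhibitor), compound 1 gives 5500 nM. For compound 2 the assay reports only a limit, > 30000 nM. For compound 3 the assay likewise reports only a limit, > 30000 nM. Compound 2 and compound 1 differ by (dimethylamino)methyl in place of carboxy on a saturated chain carbon, two bonds along the chain from an aromatic nitrogen, and this change gave an at least 5.4-fold lower number from compound 2 to compound 1 (0.73 log units; beyond the scatter), a step that can only be read as a lower bound because of the limit of > 30000 nM in this assay, at which 2 of the 3 values shown sit. How the core of compound 2 differs from the core of compound 3 is not broken down here. Compound 4, `CN(C)CCCn1nc(Cc2nnc(SCC(=O)Nc3ccc(Cl)cc3Cl)n2C)c2ccccc2c1=O`, differs from compound 3 by (dimethylamino)methyl in place of carboxy on a saturated chain carbon, two bonds along the chain from an aromatic nitrogen, the same change as before. For compound 4 a step of an at least 2.0-fold lower number from compound 3 to compound 4 (0.30 log units; that floor lies within the scatter) is expected, resting on an at least 5.4-fold lower number from compound 2 to compound 1 (0.73 log units; beyond the scatter). Compound 4 is therefore estimated at 15000 nM, between 4000 nM and 40000 nM.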

Compound 4, half-maximal inhibitory concentration: 16700 nM
Compound 4: the middle estimate sits 1.1-fold (0.05 log units) below what was measured, within the range that was stated.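

In this assay, replacing carboxy with (dimethylamino)methyl on the second core gave an at least 1.7-fold lower number from compound 3 to compound 4 (0.25 log units; that floor lies within the scatter). Both steps point the same way, which suggests that the change carries over between these two cores, but only the first floor lies beyond the scatter and their sizes cannot be compared: the same change on two cores in this assay, an at least 5.4-fold lower number (0.73 log units; beyond the scatter) from compound 2 to compound 1 and an at least 1.7-fold lower number (0.25 log units; that floor lies within the scatter) from compound 3 to compound 4; the limit leaves it open whether they differ Neither step shows how large the full effect of the change is, and both remain lower bounds because the carboxylic acids sit at a shared limit: the limit of > 30000 nM in this assay, at which 2 of the 4 values shown sit.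

The compounds shown leave open how the change would read on a third core. They also leave open whether a primary amine or a longer chain in place of 3-(dimethylamino)propyl would give a lower number.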